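Benzyl ester series: side-chain amide swapped for a second ester

The source may hold more compounds than are shown below. What is called first, only, known or untested is meant among the compounds shown, and "the series" means these compounds.

Measured compounds
Compound 1, `CC(C)[C@H](NC(=O)c1cc2ccccc2cn1)C(=O)OCc1ccccc1`: 29.7%
Compound 2, `NC(=O)C[C@H](NC(=O)c1cc2ccccc2cn1)C(=O)OCc1ccccc1`: 36.7%

In a functional assay on the whole organism (CCRF S-180 cells, Mus musculus) for inhibition, in a xenograft, with stated times of 7 days and 24 h, at a dose of 100 umol/kg by the intraperitoneal route (on this read-out lower numbers stand for less inhibition and higher numbers for more inhibition at the one dose given (going by the name of the read-out)), compound 1 gives 29.7% and compound 2 gives 36.7%. Compound 2 holds the upper of the two numbers, but the step of a number 7 percentage points higher from compound 1 to compound 2 (within the scatter) lies within the scatter, so the two measured compounds cannot be told apart on this assay.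

Compound 3, `O=C(C[C@H](NC(=O)c1cc2ccccc2cn1)C(=O)OCc1ccccc1)OCc1ccccc1`, is not yet measured. It differs from compound 2 by benzyloxy in place of amino on a carbonyl carbon. Among the compounds with values here, no measured step touches this change: the one step on record, a number 7 percentage points higher from compound 1 to compound 2 (within the scatter), alters the side chain itself rather than the group on its carbonyl carbon, and it stays within the scatter. With nothing pointing either way, the expectation is that compound 3 stays near compound 2, the expected step of a number 1.7 percentage points lower from compound 2 to compound 3 (within the scatter) being no larger than the scatter. Compound 3 is therefore estimated at 35%, within a range from 20% to 50%.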

Compound 3, a percentage reported as inhibition, in the whole organism at one dose (the size of the read-out at that dose, not a potency): 37.5%
Estimate against measurement, compound 3: 2.5 percentage points below; the measured number falls inside the stated range.
By their numbers in this assay, from the lowest: compounds 1, 2 and 3 (each within the scatter of the next).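

In this assay, amino on a carbonyl carbon gives way to benzyloxy, which brings a six-membered aromatic ring and removes a hydrogen-bond donor, and the result is a number 0.8 percentage points higher from compound 2 to compound 3 (within the scatter), so this much larger group leaves the two compounds indistinguishable on this read-out. Measured against the isopropyl compound, the full replacement by (benzyloxycarbonyl)methyl gives a number 7.8 percentage points higher from compound 1 to compound 3 (within the scatter), so all three side chains shown remain unresolved at the one dose given. No supporting data bear on these steps.

Open, as far as these compounds go, is whether a carboxylic acid on the same carbonyl carbon, or a smaller methoxy group there, would produce a step beyond the scatter. Also open, from the compounds shown here alone, is whether an amine or a longer chain on the saturated chain carbon would separate from these compounds in this assay.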